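Swapping an aziridine for a methoxyethyl chain on a quinone core

A few compounds are considered here, and "the series" means these few. Any claim that something is new, unique, unknown or untested is made for them only; others in the source may bear on it.

Measured compounds in a functional assay on L1210 cells (Mus musculus), with a stated time of 1 days; on this read-out lower numbers stand for lower potency and higher numbers for higher potency (the scale is a negative logarithm):
compound 1, `CCCC1=C(N2CC2)C(=O)C(CCC)=C(N2CC2)C1=O`: 4.32
compound 2, `CC1=C(N2CC2)C(=O)C(N2CC2)=C(N2CC2)C1=O`: 6.54
compound 3, `CCC(COC(N)=O)C1=C(N2CC2)C(=O)C(C)=C(N2CC2)C1=O`: 6.03

Compound 2 stands at the top of these three numbers. Its value is beyond the scatter above that of compound 3, and far beyond the scatter above that of compound 1, which sits lowest of all. Compound 2 is the only one of the three that carries three aziridin-1-yl groups on the shared core; compound 1 and compound 3 each carry two.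

The unmeasured compound 4, `COCCC1=C(N2CC2)C(=O)C(C)=C(N2CC2)C1=O`, is reached from compound 2 by one change: 2-methoxyethyl in place of aziridin-1-yl on a double-bonded ring carbon. The result is a core with two aziridin-1-yl groups, a methyl group and a 2-methoxyethyl chain, which places compound 4 in the same family as compound 3 rather than compound 2.

Going by the values given here, no measured pair differs in exactly this way, so no step can be read directly. The comparison of compound 2 with compound 3 and compound 1 suggests that going from three aziridin-1-yl groups to two goes with a lower number in this assay. The expected step of a number 1.04 log units lower from compound 2 to compound 4 (beyond the scatter) is therefore downward and beyond the scatter. Compound 4 is estimated at 5.5, within a range of 4.7 to 6.3.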

Compound 4, logarithm of the reciprocal of the active concentration, log(1/C): 5.19
Compound 4: middle estimate off by 0.31 log units, on the high side, and the stated range covers the measured number.
By their numbers in this assay, from the lowest: compound 1; then compound 4; then compound 3; then compound 2.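

In this assay, going by these compounds alone, putting a 2-methoxyethyl chain in place of an aziridin-1-yl group on a double-bonded ring carbon brings a number 1.35 log units lower from compound 2 to compound 4 (beyond the scatter) and gives the first change in this set that can be read at a single place. The earlier link between three aziridin-1-yl groups and a higher number rested on compounds that differ in more than one place, whereas here everything else on the shared core stays the same, so this drop belongs to this one swap at this position. What lies behind the size of the drop cannot be told from anything given here.

The swap removes a three-membered ring and adds a chain in one move, so the compounds shown cannot say whether losing the aziridin-1-yl group or gaining the 2-methoxyethyl chain counts for more. A simple ethyl group or a dimethylamino group at the same place could help separate those two parts of the change.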